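A few compounds are considered here, and "the series" means these few. Any claim that something is new, unique, unknown or untested is made for them only; others in the source may bear on it.

In a functional assay on HT-29 cells (Homo sapiens) for inhibition, read by luminescence and CellTiter-Glo, with a stated time of 24 h (a higher number here means that more compound is needed for the effect, a lower number that less compound is needed), compound 1 (`CN1C(=S)[C@@H](NC(=O)c2nc(Cc3ccccc3)n(CCCCC#N)n2)COc2ccccc21`), with 4-cyanobutyl on an aromatic nitrogen, gives 2680 nM as its value. Compound 2 (`CN1C(=S)[C@@H](NC(=O)c2nc(Cc3ccccc3)n(C3CCCC3)n2)COc2ccccc21`), with cyclopentyl on that nitrogen, gives 3530 nM as its value. These two numbers lie within the scatter of each other, so compound 2 stands level with compound 1 and neither can be ranked above the other.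

Compound 3 (`CN1C(=S)[C@@H](NC(=O)c2nc(Cc3ccccc3)n(C3CCOCC3)n2)COc2ccccc21`) alters the same place again, with oxan-4-yl in place of cyclopentyl on an aromatic nitrogen. Within the data shown here, the entering group is a six-membered non-aromatic ring with 1 hetero atom, and no measured compound has such a ring at this place.

Among the measured compounds shown here, only one measured step bears on the change (a 1.3-fold higher number from compound 1 to compound 2 (0.12 log units; within the scatter)). That step exchanged a chain for a ring on the same nitrogen and stayed within the scatter. It is a single step, so it is thin evidence, but it gives no reason to expect a step beyond the scatter in this assay in either direction. The expected step is therefore small (a 1.0-fold lower number from compound 2 to compound 3 (0.00 log units; within the scatter)). Compound 3 is estimated at 3500 nM with an expected range from 1300 nM to 9000 nM.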

Compound 3, half-maximal effective concentration: 2260 nM
For compound 3 the middle estimate is 1.5-fold (0.19 log units) above the measured one; the measured number falls inside the stated range.
By their numbers in this assay, from the lowest: compounds 3, 1 and 2 (each within the scatter of the next).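

Exchanging cyclopentyl for oxan-4-yl on the aromatic nitrogen swaps a five-membered ring of carbon only for a six-membered ring holding an oxygen, which adds one hydrogen-bond acceptor, and in this assay this gives a 1.6-fold lower number from compound 2 to compound 3 (0.19 log units; within the scatter). Against the open chain of compound 1, the same ring gives a 1.2-fold lower number from compound 1 to compound 3 (0.07 log units; within the scatter), so the 4-cyanobutyl, cyclopentyl and oxan-4-yl compounds all stand level, and a ring oxygen at this place joins the chain-for-ring exchange as a change that stays within the scatter. No independent data are at hand to explain why these three groups read alike.

Still open, from the compounds shown here alone, is whether this level holds for groups of a different kind on the same nitrogen, such as a ring amine like piperidin-4-yl, a chain ending in a carboxylic acid, or something as small as methyl. Going by these compounds, all three compounds also carry the same benzyl group and the same shared core, so whether the level persists with another group in place of benzyl remains unknown as well.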